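Aminomethyl in place of fluoro: working notes on the series

The source may hold more compounds than are shown below. What is called first, only, known or untested is meant among the compounds shown, and "the series" means these compounds.

- compound 1 `Cn1nc2c(=O)n(CC3(O)CCN(Cc4ccc(-c5ccco5)cc4Cl)CC3)cnc2c1-c1ccc(CNC=O)cc1`: 0.65 10^-6 cm/s
- compound 2 `Cn1nc2c(=O)n(CC3(O)CCN(Cc4ccc(-c5ccco5)cc4Cl)CC3)cnc2c1-c1ccc(CNCCO)cc1`: 0.36 10^-6 cm/s
- compound 3 `Cn1nc2c(=O)n(CC3(O)CCN(Cc4ccc(-c5ccco5)cc4Cl)CC3)cnc2c1-c1ccc(F)cc1`: 6.84 10^-6 cm/s

All three values come from an ADME assay on Caco-2 cells (Homo sapiens) for permeability, in the apical to basolateral direction; a higher number here means that the compound crosses the layer faster, a lower number that the compound crosses the layer more slowly. Compound 3 stands highest of the three, and its steps to both others lie beyond the scatter. The two other compounds sit close together, with a 1.8-fold lower number from compound 1 to compound 2 (0.26 log units; within the scatter).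

Compound 4 `Cn1nc2c(=O)n(CC3(O)CCN(Cc4ccc(-c5ccco5)cc4Cl)CC3)cnc2c1-c1ccc(CN)cc1` has not yet been measured. It differs from compound 3 at one place: aminomethyl in place of fluoro on an aromatic carbon. In words, this is aminomethyl in place of fluoro on an aromatic carbon, para to a large group, so 4-fluorophenyl becomes 4-(aminomethyl)phenyl.

Among the measured compounds shown here, two measured steps bear on this change, both at the same place. Fluoro in place of (formylamino)methyl gave an 11-fold higher number from compound 1 to compound 3 (1.02 log units; beyond the scatter), and fluoro in place of ((2-hydroxyethyl)amino)methyl gave a 19-fold higher number from compound 2 to compound 3 (1.28 log units; beyond the scatter). Both are large, and both favour the fluoro compound. For the measured compounds named here, neither replacing group is aminomethyl itself, and no compound with that group has been measured, so the comparison is only an analogy. A large step to a lower number is nevertheless expected, similar in size to those two. The expected step is a 14-fold lower number from compound 3 to compound 4 (1.14 log units; beyond the scatter). For compound 4 the estimated value is 0.5 10^-6 cm/s, with an expected range of 0.15 10^-6 cm/s to 1.5 10^-6 cm/s.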

Compound 4, apparent permeability: 0.92 10^-6 cm/s
Compound 4: middle estimate off by 1.8-fold (0.26 log units), on the low side; the measured number falls inside the stated range.
By their numbers in this assay, from the lowest: compounds 2, 1 and 4 (each within the scatter of the next, the first and the last beyond it); then compound 3.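

In this assay, among the compounds shown here, the step of a 7.4-fold lower number from compound 3 to compound 4 (0.87 log units; beyond the scatter) gives the first reading for the plain aminomethyl group at this place, para to a large group, and it is printed as modest, where the steps from fluoro to the two substituted aminomethyl groups were large. With aminomethyl as the reference, the step of a 1.4-fold higher number from compound 1 to compound 4 (0.15 log units; within the scatter) stays within the scatter, so hydrogen and formyl on the amine nitrogen cannot be told apart here, whereas the step of a 2.6-fold higher number from compound 2 to compound 4 (0.41 log units; beyond the scatter) lies beyond it and separates hydrogen from 2-hydroxyethyl on that nitrogen. All three compounds carrying a nitrogen on this methyl therefore stand beyond the scatter from compound 3, with no exception among those shown, and nothing at hand gives a measured reason for the size of any of these steps.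

The compounds shown leave open whether the nitrogen itself goes with the lower numbers, which a hydroxymethyl or methoxymethyl group at the same place would test. They also leave open how a tertiary amine such as dimethylaminomethyl, a carboxylic acid or a longer chain such as 2-aminoethyl would read in this assay at this place.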